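The source may hold more compounds than are shown below. What is called first, only, known or untested is meant among the compounds shown, and "the series" means these compounds.

Measured so far in a functional assay on PC-3 cells (Homo sapiens) for inhibition, read by MTT assay, with a stated time of 72 h; a higher number here means a weaker inhibitor, a lower number a stronger inhibitor:
Compound 1 `C#CCSc1nc(Nc2ccc(C)cc2)c2ccncc2n1`: 15700 nM.
Compound 2 `C#CCSc1nc(Nc2ccc([N+](=O)[O-])cc2)c2ccncc2n1`: > 80000 nM, a limit of this assay.
Compound 3 `C#CCSc1nc(Nc2ccc(OC)cc2)c2ccncc2n1`: 15100 nM.

Compound 1 holds the higher of the two numbers, with compound 3 lying within the scatter of it a 1.0-fold lower number from compound 1 to compound 3 (0.02 log units; within the scatter). Compound 2 stands only at a limit (the limit of > 80000 nM in this assay, at which 1 of the 3 values shown sits), so that an at least 5.0-fold higher number from compound 1 to compound 2 (0.70 log units; beyond the scatter) is a floor on that step.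

Compound 4 `C#CCSc1nc(Nc2cccc(O)c2)c2ccncc2n1` differs from compound 1 by 3-hydroxyphenyl in place of 4-methylphenyl on a nitrogen on an aromatic ring. Among the measured compounds shown here, no measured step tests a hydroxyl or a 3-substituted ring; the nearest comparison is the methoxy step, which stayed within the scatter, while only the nitro step moved beyond it. No step beyond the scatter is therefore expected, and compound 4 is estimated at 16000 nM, between 5000 nM and 50000 nM, a step of a 1.0-fold higher number from compound 1 to compound 4 (0.01 log units; within the scatter).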

Compound 4, half-maximal inhibitory concentration: > 80000 nM
Compound 4: a limit, no number (the forecaster's own chance of this, stated with the estimate: 15%); middle value at least 5.0-fold (0.69 log units) from the limit.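

On a nitrogen on an aromatic ring, 3-hydroxyphenyl in place of 4-methylphenyl gives an at least 5.0-fold higher number from compound 1 to compound 4 (0.70 log units; beyond the scatter) in this assay, with 7 heavy atoms both leaving and entering. A step beyond the scatter at this place is thus no longer confined to the nitro group of compound 2, while the methoxy group of compound 3 stays within the scatter of compound 1. Compound 4 stands at a limit, not a number: the limit of > 80000 nM in this assay, at which 2 of the 4 values shown sit.

The change alters the group and its ring position together, so the step cannot separate the two. On these data alone, how an amine or a carboxylic acid on this ring would read remains open.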